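Butoxycarbonyl for butyl on the aryl ring of compound 1

A few compounds are considered here, and "the series" means these few. Any claim that something is new, unique, unknown or untested is made for them only; others in the source may bear on it.

In an ADME assay on RAW264.7 cells (Mus musculus) for cytotoxicity, read by MTT assay, with a stated time of 18 h (on this read-out lower numbers stand for higher toxicity in this test and higher numbers for lower toxicity in this test), compound 1 `C=C1C(=O)OC[C@@H]1CCOC(=O)Nc1ccc(CCCC)cc1` gives 9950 nM. In this assay compound 2 `C=C1C(=O)OC[C@H]1CCOC(=O)Nc1ccc(Br)cc1` gives 8470 nM, and compound 3 `C=C1C(=O)OC[C@H]1CCOC(=O)Nc1ccc(CCCC)cc1` gives 15900 nM. Compound 1 thus stands second highest of the three numbers, compound 2 nearest and compound 3 furthest, both within the scatter. Compound 4 `C=C1C(=O)OC[C@@H]1CCOC(=O)Nc1ccc(C(=O)OCCCC)cc1` differs from compound 1 by butoxycarbonyl in place of butyl on an aromatic carbon. Within the data shown here, two measured steps bear on this: a 1.9-fold higher number from compound 2 to compound 3 (0.27 log units; within the scatter) changes the group on the same aromatic carbon, and a 1.6-fold higher number from compound 1 to compound 3 (0.20 log units; within the scatter) rests on (the fact that compounds 1 and 3 differ only in the configuration as drawn). Both lie within the scatter, so in this assay no step beyond the scatter is expected, that is a 1.0-fold higher number from compound 1 to compound 4 (0.00 log units; within the scatter). Compound 4 is estimated at 10000 nM, in the range 4000 nM to 25000 nM.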

Compound 4, half-maximal cytotoxic concentration: 12700 nM
Compound 4: middle estimate off by 1.3-fold (0.10 log units), on the low side; measured number inside the range.
By their numbers in this assay, from the lowest: compounds 2, 1, 4 and 3 (each within the scatter of the next).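

In this assay, butoxycarbonyl replaces butyl on the aromatic carbon with a 1.3-fold higher number from compound 1 to compound 4 (0.11 log units; within the scatter), so this place accepts a group bearing hydrogen-bond acceptors without a step beyond the scatter. The earlier comparison of groups here, bromo against butyl, used the other drawn configuration, while this step stays on the configuration of compound 1. Nothing at hand gives a cause for this step.

Still open, from the compounds shown here alone, is how an amine or a carboxylic acid on this aromatic carbon would read. Also open, going by these compounds, is how butoxycarbonyl would read on the configuration of compound 3.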